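Adding a Methoxy Group on Two Related Cores

A few compounds are considered here, and "the series" means these few. Any claim that something is new, unique, unknown or untested is made for them only; others in the source may bear on it.

Measured compounds:
compound 1 `COc1ccc(/C=N/c2c(C#N)ncn2-c2ccc(F)cc2)cc1` gives 19400 nM
compound 2 `COc1ccc(/C=N/c2c(C#N)ncn2-c2ccc(F)cc2)cc1OC` gives 7230 nM
compound 3 `COc1ccc(C2N=C(C(N)=O)c3ncn(-c4ccc(F)cc4)c3N2)cc1` gives 11000 nM

All three were tested in a functional assay on HT-29 cells (Homo sapiens) for antiproliferative activity, read by MTT assay, with a stated time of 48 h; on this read-out lower numbers stand for stronger inhibition and higher numbers for weaker inhibition. Compound 1 and compound 2 share one core and differ by methoxy in place of hydrogen on an aromatic carbon, which gave a 2.7-fold lower number from compound 1 to compound 2 (0.43 log units; beyond the scatter). Compound 3 carries a different core; the difference between the two cores is not broken down here. In this assay compound 3 and compound 2 lie within the scatter of each other, and so do compound 3 and compound 1, so no order among them can be read.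

Compound 4 `COc1ccc(C2N=C(C(N)=O)c3ncn(-c4ccc(F)cc4)c3N2)cc1OC` has not yet been measured. It differs from compound 3 by methoxy in place of hydrogen on an aromatic carbon, the same change, at a place described in the same words, as that from compound 1 to compound 2. Resting on that single earlier step, compound 4 is expected to show a 2.4-fold lower number from compound 3 to compound 4 (0.39 log units; beyond the scatter) in this assay. The estimate for compound 4 is therefore 4500 nM, with a likely range from 2000 nM to 12000 nM.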

Compound 4, half-maximal inhibitory concentration: 3290 nM
For compound 4 the middle estimate is 1.4-fold (0.14 log units) above the measured one; the range from low to high includes it.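

In this assay the added methoxy group gave a 3.3-fold lower number from compound 3 to compound 4 (0.52 log units; beyond the scatter), and this step matches the one seen on the other core: the same change on two cores in this assay, a 2.7-fold lower number (0.43 log units; beyond the scatter) from compound 1 to compound 2 and a 3.3-fold lower number (0.52 log units; beyond the scatter) from compound 3 to compound 4, 1.2-fold (0.10 log units) apart, within the scatter of two such steps. So within this series, the change carried from one core to the other, keeping both its direction and its size, and its effect on the number did not depend on which of these two cores carried it. Within the data shown here, this rests on only two matched pairs, with the methoxy group in one place and on one cell line, so it sets no general rule for other cores and does not explain why the number falls.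

The compounds shown leave open whether another group at the same place, such as a hydroxyl, a fluorine or a longer chain like ethoxy, would lower the number as far as methoxy does. They also leave open whether the same step would appear on a third core or in other cell lines.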